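Fluoro for hydrogen on an aromatic carbon of compound 1

The source may report more compounds than this note shows. Statements on the series, on what has been measured and on what is new or still open speak of the compounds shown alone.

Compound 1 `CC(C)CN(c1ccccc1F)S(=O)(=O)c1ccc2c(c1)C(O)CC(C1CCOCC1)O2` stands second highest of the three compounds measured in a physicochemical assay for lipophilicity, at pH 7.4; on this read-out higher numbers stand for higher lipophilicity and lower numbers for lower lipophilicity; compound 1 gives 3.39. Compound 3 `CCc1ccc(N(CC(C)C)S(=O)(=O)c2ccc3c(c2)C(O)CC(C(C)C2CCOCC2)O3)cc1` lies nearest, and in this assay compound 3 gives 5.04, a value beyond the scatter above compound 1. Compound 2 `CCc1ccc(N(CC(C)C)S(=O)(=O)c2ccc3c(c2)C(O)CC(C2CCNCC2)O3)cc1` lies furthest, and in this assay compound 2 gives 1.04, beyond the scatter below compound 1. Within the data shown here, the one step within the set, a number 4.00 log units higher from compound 2 to compound 3 (beyond the scatter), is large and sits on a saturated ring carbon.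

Compound 4 `CC(C)CN(c1ccc(F)cc1F)S(=O)(=O)c1ccc2c(c1)C(O)CC(C1CCOCC1)O2` differs from compound 1 in one place: fluoro in place of hydrogen on an aromatic carbon. Cut one bond further out, the change reads 2-fluorophenyl to 2,4-difluorophenyl. Among the measured compounds shown here, no measured step covers a fluoro for hydrogen exchange on an aromatic carbon; the step of a number 4.00 log units higher from compound 2 to compound 3 (beyond the scatter) touches a different part of the shared core and does not bear on it. Without a matching precedent, the expectation for this assay is a small upward move, probably not beyond the scatter. Compound 4 is estimated at 3.65, with a range from 3.3 to 4. This estimate corresponds to an expected step of a number 0.26 log units higher from compound 1 to compound 4 (within the scatter).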

Compound 4, distribution coefficient: 3.53
Compound 4: the middle estimate sits 0.12 log units above what was measured; the measured number falls inside the stated range.
By their numbers in this assay, from the lowest: compound 2; then compounds 1 and 4 (each within the scatter of the next); then compound 3.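

Fluoro in place of hydrogen on an aromatic carbon, para to a large group, turning 2-fluorophenyl into 2,4-difluorophenyl, comes out in this assay as a number 0.14 log units higher from compound 1 to compound 4 (within the scatter) and is the first measured step at this aromatic ring. Among these compounds, the only earlier step, a number 4.00 log units higher from compound 2 to compound 3 (beyond the scatter), lies on a saturated ring carbon and is large, whereas this single exchange stays inside the scatter, so on the background of compound 1 this position takes a second fluoro with no readable change in this read-out. Nothing available accounts for the size of this step.

Still open, from the compounds shown here alone, is whether a larger or different group at this same position, such as chloro, methoxy or a carboxylic acid, would shift the read-out beyond the scatter. Also open, going by these compounds, is whether fluoro for hydrogen here gives a similar step when piperidin-4-yl, as in compound 2, stands on the saturated ring carbon in place of oxan-4-yl.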